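Naphthyl in Place of Cyanophenyl: an Expected Loss

This account rests on a few compounds, and the source may have more. Where it says the series, first, only, none or still open, it means among the compounds named here.

Of the compounds shown here, three sharing one core have been tested in a functional assay on A549 cells (Homo sapiens) for antiproliferative activity, read by MTT assay, with a stated time of 72 h; on this read-out higher numbers stand for weaker inhibition and lower numbers for stronger inhibition. Compound 1 `NC(=S)N1N=C(c2ccc(N3CCCCC3)cc2)CC1c1ccc(Cl)cc1` gives 33800 nM. Compound 2 `Clc1ccc(-c2csc(N3N=C(c4ccc(N5CCCCC5)cc4)CC3c3ccc(Cl)cc3)n2)cc1` gives 46400 nM, a step of a 1.4-fold higher number from compound 1 to compound 2 (0.14 log units; within the scatter). Compound 3 `N#Cc1ccc(-c2csc(N3N=C(c4ccc(N5CCCCC5)cc4)CC3c3ccc(Cl)cc3)n2)cc1` gives 11200 nM, the lowest number of the three, reached by a 4.1-fold lower number from compound 2 to compound 3 (0.62 log units; beyond the scatter).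

Compound 4 `Clc1ccc(C2CC(c3ccc(N4CCCCC4)cc3)=NN2c2nc(-c3ccc4ccccc4c3)cs2)cc1` differs from compound 3 in one place: naphthalen-2-yl in place of 4-cyanophenyl on an aromatic carbon. Among the measured compounds shown here, no measured step makes this exact exchange. For the measured compounds named here, the only step that touches the same position is a 4.1-fold lower number from compound 2 to compound 3 (0.62 log units; beyond the scatter), where the compound carrying the cyano group gave the clearly lower number. Compound 4 carries no cyano group, so in this assay a step back toward the numbers of compound 1 and compound 2 is expected, of about a 3.1-fold higher number from compound 3 to compound 4 (0.49 log units; beyond the scatter). Because compound 2, which also lacks the cyano group, gave 46400 nM, compound 4 is expected to give 35000 nM, with a likely range from 12000 nM to 100000 nM.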

Compound 4, half-maximal inhibitory concentration: > 100000 nM
Compound 4 gave a limit, no number; the forecaster's own chance of this, stated with the estimate: 10%; middle value at least 2.8-fold (0.45 log units) from the limit.
By their numbers in this assay, from the lowest: compound 3; then compounds 1 and 2 (each within the scatter of the next). At a limit, above all of these: compound 4.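

In this assay, compound 4 gives a limit, not a number: the limit of > 100000 nM in this assay, at which 1 of the 4 values shown sits. Placing naphthalen-2-yl on this aromatic carbon gives an at least 8.9-fold higher number from compound 3 to compound 4 (0.95 log units; beyond the scatter), and the same group gives an at least 2.1-fold higher number from compound 2 to compound 4 (0.33 log units; beyond the scatter). The earlier compounds shown here showed only that this position responds to a change at the far end of a single phenyl ring, whereas these steps show that replacing the whole group also matters, with both phenyl compounds giving lower numbers than the compound with two fused rings.

As far as these compounds go, the true size of both steps remains unknown, since each rests on a limit, and nothing here separates the effect of the second ring from the loss of the phenyl substituent. Also open, from the compounds shown here alone, is how a plain phenyl, or a phenyl carrying an amine or a carboxylic acid, would read at this position.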